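The source may hold more compounds than are shown below. What is called first, only, known or untested is meant among the compounds shown, and "the series" means these compounds.

Measured in an ADME assay on WI-38 cells (Homo sapiens) for cytotoxicity, read by sulforhodamine B assay, with a stated time of 24 h; on this read-out lower numbers stand for stronger inhibition and higher numbers for weaker inhibition:

- compound 1 `N=c1oc2ccccc2cc1C(=O)N/N=C1\C(=O)Nc2ccc(S(=O)(=O)N3CCOCC3)cc21`: 132000 nM
- compound 2 `O=C1Nc2ccc(S(=O)(=O)N3CCOCC3)cc2/C1=N/c1ccc(C(=O)O)cc1`: 313000 nM
- compound 3 `COc1ccc(-c2c(C#N)c(N)n(/N=C3\C(=O)Nc4ccc(S(=O)(=O)N5CCOCC5)cc43)c(=O)c2C#N)cc1`: 224000 nM

Compound 2 stands at the highest number of the three in this assay. Compound 3 sits within the scatter of compound 2, so the two are not told apart; compound 1 lies beyond the scatter at a lower number. Among the measured compounds shown here, no pair of measured compounds differs in a single place, so no step from this series can be carried over directly.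

Compound 4 `O=C1Nc2ccc(S(=O)(=O)N3CCOCC3)cc2/C1=N/Nc1ccccc1` differs from compound 2 by anilino in place of 4-carboxyphenyl on a double-bonded nitrogen. For this assay a step no larger than the scatter is expected, if anything toward a lower number. Compound 4 is thus estimated at 200000 nM, range 80000 nM to 500000 nM, which means an expected step of a 1.6-fold lower number from compound 2 to compound 4 (0.19 log units; within the scatter).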

Compound 4, half-maximal inhibitory concentration: 262000 nM
Compound 4: middle estimate off by 1.3-fold (0.12 log units), on the low side, and the stated range covers the measured number.
By their numbers in this assay, from the lowest: compounds 1, 3, 4 and 2 (each within the scatter of the next, the first and the last beyond it).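

In this assay, a 1.2-fold lower number from compound 2 to compound 4 (0.08 log units; within the scatter) stays within the scatter, so anilino and 4-carboxyphenyl on the double-bonded nitrogen are not told apart. Among the compounds shown here, this is the first single-place comparison, and it shows that this exchange, which removes the carboxylic acid, leaves the read-out unresolved. Nothing measured here gives a reason for this result. Still open, as far as these compounds go, is whether a simple alkyl chain, such as butyl, on the double-bonded nitrogen would give a step beyond the scatter. Also open, from the compounds shown here alone, is whether a chlorine or a dimethylamino group on the aromatic ring would do so.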